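Swapping a nitrile-bearing ring for a methylpyridine ring

The source may report more compounds than this note shows. Statements on the series, on what has been measured and on what is new or still open speak of the compounds shown alone.

Three compounds built on the shared core of compound 1 `CC/C(=C(/c1ccc(/C=C/C(=O)O)cc1)c1ccc2[nH]ccc2c1)c1ccccc1` have been measured in a functional assay on MCF7 cells (Homo sapiens) for cytotoxicity, read by CellTiter-Glo, with a stated time of 5 days; on this read-out higher numbers stand for weaker inhibition and lower numbers for stronger inhibition. In this assay compound 1 gives 9 nM, and compound 2 `CC/C(=C(\c1ccc2[nH]ncc2c1)c1ccc(/C=C/C(=O)O)cc1OC)c1ccccc1` gives 12 nM. Compound 3 `CC/C(=C(/c1ccc(/C=C/C(=O)O)cc1)c1ccc2[nH]ncc2c1)c1cccc(C#N)c1` gives 100 nM, the highest of the three numbers; the nearest of the others is compound 2, and the furthest is compound 1, both well beyond the usual scatter. Within the data shown here, compound 1 and compound 3 differ in more than one place, so their values show only that the compound carrying a 3-cyanophenyl group here is weaker.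

Compound 4 `CC/C(=C(/c1ccc(/C=C/C(=O)O)cc1)c1ccc2[nH]ncc2c1)c1cnccc1C` is not yet measured. It differs from compound 3 in one place: 4-methylpyridin-3-yl in place of 3-cyanophenyl on a double-bonded chain carbon bound to a double-bonded chain carbon and a saturated chain carbon. Among the measured compounds shown here, no measured pair shows this particular change. Since compound 3 gives 100 nM, the highest number in the set, there is room for the number to fall, and the expected step from compound 3 to compound 4 is estimated as a modest decrease, a 2.5-fold lower number from compound 3 to compound 4 (0.40 log units; beyond the scatter). For compound 4 the value in this assay is estimated at 40 nM, with a range from 10 nM to 160 nM.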

Compound 4, half-maximal inhibitory concentration: 150 nM
Beside the measured number, compound 4's estimate is 3.8-fold (0.57 log units) below it; low and high end bracket the measured number.
By their numbers in this assay, from the lowest: compounds 1 and 2 (each within the scatter of the next); then compounds 3 and 4 (each within the scatter of the next).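

In this assay, putting 4-methylpyridin-3-yl in place of 3-cyanophenyl on this chain carbon gives a 1.5-fold higher number from compound 3 to compound 4 (0.18 log units; within the scatter), so this assay does not tell the two groups apart. Among these compounds, this is the first comparison in the set that changes this position alone, and it shows that the position accepts a nitrogen-containing ring with a methyl group as well as a carbon-only ring with a nitrile, with no step beyond the scatter. Nothing measured here accounts for the two groups reading alike.

From the compounds shown here alone, the methyl group and the ring nitrogen enter together in this one step, so their separate contributions remain open. Also open, going by these compounds, is what a ring carrying an amine, or an open isopropyl chain in place of the ring, would do at this position.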